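This account rests on a few compounds, and the source may have more. Where it says the series, first, only, none or still open, it means among the compounds named here.

Measured so far:
- Compound 1 `CC(C)n1ncc2c(C(=O)NCc3cn(-c4cccc(F)c4)nn3)cccc21`: in a functional assay on MGC-803 cells (Homo sapiens) for inhibition, read by MTT assay, with a stated time of 72 h (on this read-out lower numbers stand for stronger inhibition and higher numbers for weaker inhibition), compound 1 gives only the assay limit, > 40000 nM.
- Compound 2 `Cc1cccc(-n2cc(CNC(=O)c3cccc4c3cnn4C(C)C)nn2)c1`: in this assay compound 2 gives only the assay limit, > 40000 nM.
- Compound 3 `Cc1ccccc1-n1cc(CNC(=O)c2cccc3c2cnn3C(C)C)nn1`: in this assay compound 3 gives only the assay limit, > 40000 nM.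

Among the measured compounds shown here, all three values sit at the limit of > 40000 nM in this assay, at which 3 of the 3 values shown sit, so no measured step in this set can be sized. The change from compound 2 to compound 1 is fluoro in place of methyl on an aromatic carbon, and its step is a step that the two limits leave unreadable from compound 2 to compound 1. The two cores differ as 2-methylphenyl in place of 3-methylphenyl on an aromatic nitrogen, with the step that the two limits leave unreadable from compound 2 to compound 3. Compound 4 `CC(C)n1ncc2c(C(=O)NCc3cn(-c4ccccc4F)nn3)cccc21`, not yet measured, carries the same kind of change from compound 3: fluoro in place of methyl on an aromatic carbon. Around the place the two differ: in compound 1 the fluoro is meta to a large group, in compound 4 ortho to a large group.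

With every value at the limit of > 40000 nM in this assay, at which 3 of the 3 values shown sit, the step from compound 3 to compound 4 is expected to be a step that the limit leaves unreadable from compound 3 to compound 4. Compound 4 is therefore expected to give 60000 nM in this assay, between 20000 nM and 200000 nM, most likely again as a limit.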

Compound 4, half-maximal inhibitory concentration: > 40000 nM
Compound 4 ended at the assay's limit; the forecaster's own chance of this, stated with the estimate: 85%; the middle value lies beyond the limit too.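

No step among compound 1, compound 2, compound 3 and compound 4 can be read in this assay, because all four values are limits rather than numbers: the limit of > 40000 nM in this assay, at which 4 of the 4 values shown sit.

The compounds shown leave open whether 2-fluorophenyl, 3-fluorophenyl, 2-methylphenyl and 3-methylphenyl differ at all in inhibition, and whether any change to the shared core gives a measurable value.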